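Nitro in Place of Hydrogen on a Thiophene Alkyne Ether

The source may hold more compounds than are shown below. What is called first, only, known or untested is meant among the compounds shown, and "the series" means these compounds.

Measured compounds:
compound 1 `CC(C)(O)C#Cc1cccs1` — 78%
compound 2 `C(#Cc1cccs1)COc1ccccc1` — 47%

Of the compounds shown here, two have so far been measured in a functional assay on LoVo cells (Homo sapiens) for inhibition, tested at 100 uM; a higher number here means more inhibition at the concentration tested (going by the name of the read-out), a lower number less inhibition. Compound 1 `CC(C)(O)C#Cc1cccs1` gives 78% in this assay, while compound 2 `C(#Cc1cccs1)COc1ccccc1` gives 47%. Compound 2 therefore stands at the lower of the two numbers, and its gap to compound 1 lies beyond the usual scatter of repeated measurements.

Compound 3 `O=[N+]([O-])c1ccc(OCC#Cc2cccs2)cc1` has not yet been measured in this assay. Its structure differs from that of compound 2 by nitro in place of hydrogen on an aromatic carbon. Among the compounds with values here, no measured pair of compounds shows what this exchange does in this assay, so neither the direction nor the size of the step can be read from the numbers at hand. The step is expected to be modest, a number 5 percentage points higher from compound 2 to compound 3 (within the scatter), and may well fall within the scatter. Compound 3 is estimated to give about 52% in this assay, within a range from 28% to 76%.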

Compound 3, a percentage reported as inhibition, at one concentration (the size of the read-out at that concentration, not a potency): 26%
Estimate against measurement, compound 3: 26 percentage points above; the measured number lies below the stated range.
By their numbers in this assay, from the lowest: compound 3; then compound 2; then compound 1.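

This is the only change in one place among the compounds shown, and it gives the first direct reading of the six-membered aromatic ring in this assay as a site of substitution. Nitro in place of hydrogen on an aromatic carbon, para to a group of 9 heavy atoms, gives a number 21 percentage points lower from compound 2 to compound 3 (beyond the scatter) and so shows that this position is not indifferent to the change. No measured property of these compounds accounts for this step, and the reason for it remains unknown.

A single substituent at a single carbon cannot show whether the loss belongs to nitro itself or would follow from other groups there, such as an amine, a methoxy group or a carboxylic acid. On these data alone, whether nitro would have the same effect on the other carbons of that ring also remains open.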